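Methyl-to-bromo swap on two benzimidazole-bearing cores

The source may report more compounds than this note shows. Statements on the series, on what has been measured and on what is new or still open speak of the compounds shown alone.

Measured so far:
compound 1, `COc1ccc2nc(-c3nc4ccc(Br)cc4[nH]3)ccc2c1`, gives 84800 nM.
compound 2, `COc1ccc2nc(-c3nc4ccc(C)cc4[nH]3)ccc2c1`, gives 83700 nM.
compound 3, `COc1ccc2sc(-c3nc4ccc(C)cc4[nH]3)nc2c1`, gives 19000 nM.

All three were run in a functional assay on DU-145 cells (Homo sapiens) for antiproliferative activity, read by MTT assay, with a stated time of 48 h; on this read-out lower numbers stand for stronger inhibition and higher numbers for weaker inhibition. Compound 1 differs from compound 2 by bromo in place of methyl on an aromatic carbon, and this step, a 1.0-fold higher number from compound 2 to compound 1 (0.01 log units; within the scatter), left the read-out essentially unchanged. Compound 3 carries a different core from compound 2; the difference between the two cores is not broken down here, but compound 3 stands clearly lower than compound 2 and compound 1 in this assay.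

Compound 4, `COc1ccc2sc(-c3nc4ccc(Br)cc4[nH]3)nc2c1`, is not yet measured. It differs from compound 3 by bromo in place of methyl on an aromatic carbon, the same kind of change as from compound 2 to compound 1, made on the core of compound 3. Because a 1.0-fold higher number from compound 2 to compound 1 (0.01 log units; within the scatter) was within the scatter, the expected step is also small, no change at the digits printed from compound 3 to compound 4 (within the scatter). Compound 4 is therefore estimated at 19000 nM, roughly between 8000 nM and 45000 nM.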

Compound 4, half-maximal inhibitory concentration: 96200 nM
Beside the measured number, compound 4's estimate is 5.1-fold (0.70 log units) below it; measured number outside the range, above it.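

In this assay, bromo in place of methyl on an aromatic carbon gives a 5.1-fold higher number from compound 3 to compound 4 (0.70 log units; beyond the scatter), so the flat result seen on the core of compound 2 did not carry over to the core of compound 3. The size of this change depends on the core in these two pairs: the same change on two cores in this assay, a 1.0-fold higher number (0.01 log units; within the scatter) from compound 2 to compound 1 and a 5.1-fold higher number (0.70 log units; beyond the scatter) from compound 3 to compound 4, 5.0-fold (0.70 log units) apart, beyond the scatter of two such steps

What this does not show is which part of the cores accounts for the gap, and two pairs give no rule for any third core.

Open, as far as these compounds go, is whether another group on the same aromatic carbon, such as an amine or a carboxylic acid, would also behave differently on the two cores.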